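Chalcone series: halogen-to-methyl swap on the ketone-side ring

The compounds below may be only part of what the source reports. "The series", "measured", "known", "first", "only" and "open" are said of these compounds alone.

Measured so far:
compound 1 `Cc1ccc(C(=O)/C=C/c2cc(Cl)ccc2O)cc1` — 4800 nM
compound 2 `O=C(/C=C/c1cc(Br)ccc1O)c1ccc(Br)cc1` — 5880 nM

In a functional assay on Hs-578T cells (Homo sapiens) for antiproliferative activity, read by sulforhodamine B assay, with a stated time of 72 h (a lower number here means a stronger inhibitor, a higher number a weaker inhibitor), compound 1 gives 4800 nM and compound 2 gives 5880 nM. Going by the values given here, compound 2 carries the highest number of the two, but the gap to compound 1 is within the scatter, so the two cannot be told apart on these numbers; no pair here differs in a single place, so no step between measured compounds is available.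

Compound 3 `Cc1ccc(C(=O)/C=C/c2cc(Br)ccc2O)cc1` is not yet measured in this assay. Against compound 2 the change is methyl in place of bromo on an aromatic carbon. Compound 1 also carries a methyl group and a halogen on the other ring, and with that combination compound 1 gives 4800 nM, a number indistinguishable from compound 2. On that basis the step from compound 2 to compound 3 is expected to stay within the scatter, with no direction to call; the expected step is a 1.1-fold lower number from compound 2 to compound 3 (0.05 log units; within the scatter). Compound 3 is therefore estimated at 5200 nM in this assay, with a range from 2500 nM to 11000 nM.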

Compound 3, half-maximal inhibitory concentration: 1600 nM
Beside the measured number, compound 3's estimate is 3.3-fold (0.51 log units) above it, and the stated range ends above it.
By their numbers in this assay, from the lowest: compound 3; then compounds 1 and 2 (each within the scatter of the next).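

In this assay, the two single-place steps show that both halogen sites affect the number, which the earlier pair could not show because compounds 1 and 2 differ in two places. Methyl in place of bromo on an aromatic carbon, para to a large group, gives a 3.7-fold lower number from compound 2 to compound 3 (0.57 log units; beyond the scatter), so this position is sensitive to the change, and methyl is the better of the two groups tested there with bromo held on the other ring. Bromo in place of chloro on an aromatic carbon of the other ring gives a 3.0-fold lower number from compound 1 to compound 3 (0.48 log units; beyond the scatter), a modest step that is also beyond the scatter, while no available measurement explains either step.

On these data alone, it remains open whether the methyl preference holds with chloro on the other ring, and whether the bromo preference holds with bromo rather than methyl at the para position. Also open, as far as these compounds go, is how an ethyl group, a methoxy group or an amine would compare with methyl at that position, and how iodo would compare with bromo on the other ring.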